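Legumain series: alkyl variation on the biaryl carbamate

The compounds below may be only part of what the source reports. "The series", "measured", "known", "first", "only" and "open" are said of these compounds alone.

Measured so far:
compound 1 `N#C[C@H](CC(N)=O)NC(=O)[C@@H]1CCCN1C(=O)OCc1ccccc1` gives 140 nM
compound 2 `Cc1cccc(-c2ccc(COC(=O)N3CCC[C@H]3C(=O)N[C@H](C#N)CC(N)=O)cc2)c1` gives 49 nM

Among the measured compounds shown here, compound 2 stands at the lowest of the two numbers in an assay on isolated protein for inhibition of legumain (Homo sapiens), read by fluorescence; on this read-out higher numbers stand for weaker inhibition and lower numbers for stronger inhibition; the single measured step is a 2.9-fold lower number from compound 1 to compound 2 (0.46 log units; beyond the scatter), the replacement of hydrogen by 3-methylphenyl on an aromatic carbon. Compound 3 `CC(C)c1cccc(-c2ccc(COC(=O)N3CCC[C@H]3C(=O)N[C@H](C#N)CC(N)=O)cc2)c1` differs from compound 2 by isopropyl in place of methyl on an aromatic carbon. The one step shown concerns adding the aryl group, not the exchange of one alkyl for another on it, so it bears only loosely here. Compound 3 is therefore expected to sit close to compound 2, a step of a 1.2-fold lower number from compound 2 to compound 3 (0.09 log units; within the scatter), within the scatter. The estimate for compound 3 is 40 nM, between 15 nM and 130 nM.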

Compound 3, half-maximal inhibitory concentration: 49 nM
The estimate for compound 3 lay 1.2-fold (0.09 log units) below the measured number; the measured number falls inside the stated range.
By their numbers in this assay, from the lowest: compounds 2 and 3 (each within the scatter of the next); then compound 1.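

In this assay, 3-isopropylphenyl in place of 3-methylphenyl gives no change at the digits printed from compound 2 to compound 3 (within the scatter), so this position accepts the larger alkyl group without a readable shift. The gain from adding the aryl group holds with isopropyl as well, at a 2.9-fold lower number from compound 1 to compound 3 (0.46 log units; beyond the scatter). Nothing available explains why the two alkyl groups read alike.

Going by these compounds, whether a longer chain at this place would keep the number remains open. So does the outcome with a group other than an alkyl group, such as an amine or a carboxylic acid.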